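The compounds below may be only part of what the source reports. "The series", "measured", "known", "first", "only" and "open" are said of these compounds alone.

Measured so far:
compound 1 `CCn1c(N[C@H]2CC[C@H](C(=O)OC)CC2)nc2ccsc2c1=O`: 13 ug/mL
compound 2 `CCn1c(NC(C)C)nc2c(-c3ccco3)csc2c1=O`: 0.1 ug/mL

In a physicochemical assay for solubility, in phosphate buffer, at pH 6.8 (on this read-out lower numbers stand for lower solubility and higher numbers for higher solubility), compound 1 stands highest of the two at 13 ug/mL, and compound 2 gives 0.1 ug/mL. The gap between these two values lies beyond the scatter. Compound 3 `CCn1c(N[C@H]2CC[C@H](O)CC2)nc2ccsc2c1=O` has hydroxy in place of methoxycarbonyl on a saturated ring carbon. Going by the values given here, no measured pair shows this change, so the expectation rests on the structures alone. A moderate rise in this assay is expected, although a step within the scatter remains possible. The expected step is a 3.1-fold higher number from compound 1 to compound 3 (0.49 log units; beyond the scatter). For compound 3 the estimated value is 40 ug/mL, with an expected range from 10 ug/mL to 150 ug/mL.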

Compound 3, solubility: 74 ug/mL
For compound 3 the middle estimate is 1.9-fold (0.27 log units) below the measured one; low and high end bracket the measured number.
By their numbers in this assay, from the lowest: compound 2; then compound 1; then compound 3.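

In this assay, hydroxy in place of methoxycarbonyl on a saturated ring carbon gives a 5.7-fold higher number from compound 1 to compound 3 (0.76 log units; beyond the scatter). Going by these compounds alone, this is the first single-place comparison, and it shows that the read-out responds to the group at this position, which compound 1 and compound 2 could not show because they differ in more than one place. No measurement given here accounts for the size of this step. On these data alone, whether an amine or a carboxylic acid at this ring carbon would give a higher or lower number remains open. As far as these compounds go, it is also open whether hydroxy would give a similar step on a different core.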